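The compounds below may be only part of what the source reports. "The series", "measured", "known", "first", "only" and "open" are said of these compounds alone.

In a functional assay on the whole organism with Rattus norvegicus as the target (a lower number here means that less compound is needed, a higher number that more compound is needed for the effect), two related esters have been measured so far. For compound 1 `CCOC(=O)C(=O)Nc1cc(N(C)C)ccc1C#N`, the result is only a limit, > 100 mg/kg. For the measured compounds named here, compound 2 `CCOC(=O)C(=O)Nc1cccc(N(C)C(C)C)c1C#N` gives 1.2 mg/kg, the only true number available, so it has no measured number to be ranked against.

Compound 3 `CCOC(=O)C(=O)Nc1cccc(F)c1C#N` differs from compound 2 at a single site: fluoro in place of isopropyl(methyl)amino on an aromatic carbon. In words, this is fluoro in place of isopropyl(methyl)amino on an aromatic carbon, ortho to a cyano group. Going by the values given here, no measured pair shows what this exchange does in this assay, so any forecast is rough. A rise in the dose needed is the likelier direction, because compound 2 at 1.2 mg/kg already works at a low dose. The expected step is a 6.7-fold higher number from compound 2 to compound 3 (0.82 log units; beyond the scatter), which would lie beyond the usual scatter, though its size is uncertain. For compound 3, the estimated dose is 8 mg/kg, with an expected range of 1.5 mg/kg to 50 mg/kg.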

Compound 3, dose for half-maximal effect: 59 mg/kg
Compound 3: the middle estimate sits 7.4-fold (0.87 log units) below what was measured; measured number outside the range, above it.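

In this assay, the place ortho to a cyano group turns out to matter a great deal: fluoro in place of isopropyl(methyl)amino gives a 49-fold higher number from compound 2 to compound 3 (1.69 log units; beyond the scatter). A single fluorine atom therefore does not stand in for this amino group of 5 heavy atoms, although one exchange cannot tell which feature of that group counts. Compound 3 still gives a true number, whereas compound 1 is the one compound held at a limit, which is not a number: the limit of > 100 mg/kg in this assay, at which 1 of the 3 values shown sits.

Still open, from the compounds shown here alone, is whether the nitrogen or the attached carbon groups carry the effect at this place. A plain amino group, a methoxy group or a diethylamino group there would help separate these two possibilities.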